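Fluorine on the Pendant Phenyl of a Cyclic Amide Series

A few compounds are considered here, and "the series" means these few. Any claim that something is new, unique, unknown or untested is made for them only; others in the source may bear on it.

Compound 2, `O=C1COc2ccc(-c3cnc(Cl)c(NS(=O)(=O)c4ccc(F)cc4)c3)cc2N1c1ccccc1`, is tested in a functional assay on A-375 cells (Homo sapiens) for antiproliferative activity, read by MTT assay, with a stated time of 72 h (a lower number here means a stronger inhibitor, a higher number a weaker inhibitor), where compound 2 gives 36900 nM. Among the measured compounds shown here, that is the only number available here; one further value is a limit. Its close relative compound 1, `COc1cccc(N2C(=O)COc3ccc(-c4cnc(Cl)c(NS(=O)(=O)c5ccc(F)cc5)c4)cc32)c1`, carries a methoxy group on the same ring, and in this assay compound 1 gives > 40000 nM, which is a limit of the assay rather than a number. The step of an at least 1.0-fold lower number from compound 1 to compound 2 (0.03 log units; that floor lies within the scatter) is thus bounded by the limit of > 40000 nM in this assay, at which 1 of the 2 values shown sits, and shows only that hydrogen in place of methoxy on this ring stays within the scatter.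

Compound 3, `O=C1COc2ccc(-c3cnc(Cl)c(NS(=O)(=O)c4ccc(F)cc4)c3)cc2N1c1ccc(F)cc1`, differs from compound 2 by fluoro in place of hydrogen on an aromatic carbon; seen one bond further out, the change reads phenyl to 4-fluorophenyl. For the measured compounds named here, no measured step covers fluoro at this position, and the only step available, an at least 1.0-fold lower number from compound 1 to compound 2 (0.03 log units; that floor lies within the scatter), concerns the same ring and is small. The expected step in this assay is therefore a 1.2-fold lower number from compound 2 to compound 3 (0.09 log units; within the scatter), that is, none beyond the scatter. Compound 3 is estimated to give 30000 nM in this assay, with a range from 12000 nM to 60000 nM.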

Compound 3, half-maximal inhibitory concentration: > 40000 nM
Compound 3 gave a limit, no number; the forecaster's own chance of this, stated with the estimate: 35%; at least 1.3-fold (0.12 log units) between middle value and limit.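

In this assay, fluoro in place of hydrogen on an aromatic carbon, para to a large group, gives an at least 1.0-fold higher number from compound 2 to compound 3 (0.03 log units; that floor lies within the scatter), so the change from phenyl to 4-fluorophenyl brings no sign of a lower number. The value of compound 3 is a limit of the assay, and the step from compound 1 to compound 3 cannot be read, as both values are limits. A substituent has now been tried at this position as well, yet only compound 2 gives a number, and every comparison in the series is bounded by one ceiling: the limit of > 40000 nM in this assay, at which 2 of the 3 values shown sit.

From the compounds shown here alone, how far the true values of compound 1 and compound 3 lie past that limit stays open, so neither group can be placed relative to hydrogen beyond what the limit allows. Also open, going by these compounds, is whether an amine or a carboxylic acid at this position on the pendant ring would give a number clearly lower than that of compound 2.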